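Swapping the Aryl Group on a Ring Nitrogen

The compounds below may be only part of what the source reports. "The series", "measured", "known", "first", "only" and "open" are said of these compounds alone.

Of the compounds shown here, two have been measured so far. Compound 1 `N#CC1=C(N)Oc2c(N)cc3nc4ccccc4nc3c2C12C(=O)N(Cc1cnnn1-c1ccccc1Br)c1ccccc12` gives 30700 nM in a functional assay on MCF7 cells (Homo sapiens) for antiproliferative activity, read by MTT assay, with a stated time of 48 h; a higher number here means a weaker inhibitor, a lower number a stronger inhibitor. Compound 2 `COc1ccccc1-n1nncc1CN1C(=O)C2(C(C#N)=C(N)Oc3c(N)cc4nc5ccccc5nc4c32)c2ccccc21` differs from it only by a methoxy in place of bromo on an aromatic carbon, and in this assay compound 2 gives 28900 nM. That step is a 1.1-fold lower number from compound 1 to compound 2 (0.03 log units; within the scatter), so the two numbers cannot be told apart, and compound 2 simply stands alongside compound 1 as one of two near-identical results.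

Compound 3 `N#CC1=C(N)Oc2c(N)cc3nc4ccccc4nc3c2C12C(=O)N(Cc1cnnn1-c1ccc([N+](=O)[O-])cc1)c1ccccc12` has not been measured. It differs from compound 2 by 4-nitrophenyl in place of 2-methoxyphenyl on an aromatic nitrogen. Among the compounds with values here, the only measured step bearing on this part of the molecule is a 1.1-fold lower number from compound 1 to compound 2 (0.03 log units; within the scatter), where exchanging one substituent for another on the same phenyl ring left the number essentially unchanged. The new change replaces the whole 2-methoxyphenyl with a 4-nitrophenyl, which is a broader exchange, but nothing measured points in either direction. Compound 3 is therefore expected to show no step beyond the scatter, with a 1.0-fold higher number from compound 2 to compound 3 (0.02 log units; within the scatter) as the estimated step. The value estimated for compound 3 in this assay is 30000 nM, with a range from 10000 nM to 90000 nM.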

Compound 3, half-maximal inhibitory concentration: > 50000 nM
Compound 3 ended at the assay's limit; the forecaster's own chance of this, stated with the estimate: 15%; at least 1.6-fold (0.22 log units) between middle value and limit.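

In this assay the result for compound 3 is a limit of the assay and not a number: the limit of > 50000 nM in this assay, at which 1 of the 3 values shown sits.

All that can be read is a floor, with an at least 1.7-fold higher number from compound 2 to compound 3 (0.23 log units; that floor lies within the scatter) and an at least 1.6-fold higher number from compound 1 to compound 3 (0.21 log units; that floor lies within the scatter), so the real gap could be small or much larger, and neither step can be called a true loss of activity. Within the data shown here, the earlier exchange of bromo for methoxy gave a 1.1-fold lower number from compound 1 to compound 2 (0.03 log units; within the scatter) and left two readable values, whereas this wider exchange on the aromatic nitrogen of the five-membered ring is the first to leave the measurable range, which hints that this position may not be indifferent to the aryl group without proving it.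

4-Nitrophenyl differs from 2-methoxyphenyl and 2-bromophenyl both in its substituent and in where that substituent sits on the phenyl ring, so the compounds shown cannot separate those two changes. They also leave open how this position would respond to a plain phenyl, an amine on the phenyl ring or a longer chain in place of the ring.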